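Swapping the benzyl substituent on a dithiocarbamate piperazine

The source may report more compounds than this note shows. Statements on the series, on what has been measured and on what is new or still open speak of the compounds shown alone.

Measured so far:
compound 1 `S=C(SCc1cn(Cc2ccccc2Cl)nn1)N1CCNCC1` — 38900 nM
compound 2 `Cc1cc(=O)oc2cc(OCCn3cc(CSC(=S)N4CCN(C(=O)OC(C)(C)C)CC4)nn3)ccc12` — 90400 nM

Of the two compounds tested in a functional assay on MCF7 cells (Homo sapiens) for inhibition, read by MTT assay, with a stated time of 72 h (a lower number here means a stronger inhibitor, a higher number a weaker inhibitor), compound 1 holds the lower number, 38900 nM. Compound 2, which shares only part of its framework, gives 90400 nM in this assay, a gap beyond the usual scatter. Compound 3 `Cc1ccc(Cn2cc(CSC(=S)N3CCNCC3)nn2)cc1` has not yet been measured. It differs from compound 1 in one place: 4-methylphenyl in place of 2-chlorophenyl on a saturated chain carbon bound to an aromatic nitrogen. Going by the values given here, no measured pair in this set isolates such a change, so there is nothing to lean on beyond the value of compound 1 itself. Exchanging one unsubstituted aromatic substituent for another of equal size, with no change in donors, acceptors or charge, is expected to move the number little, so the step of a 1.2-fold higher number from compound 1 to compound 3 (0.06 log units; within the scatter) is estimated to stay within the scatter. Compound 3 is therefore expected to give about 45000 nM in this assay, with a plausible range from 15000 nM to 130000 nM.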

Compound 3, half-maximal inhibitory concentration: 53200 nM
For compound 3 the middle estimate is 1.2-fold (0.07 log units) below the measured one; the measured number falls inside the stated range.
By their numbers in this assay, from the lowest: compounds 1, 3 and 2 (each within the scatter of the next, the first and the last beyond it).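

Going by these compounds alone, this is the first pair in the set that differs in one place. In this assay, replacing 2-chlorophenyl with 4-methylphenyl on a saturated chain carbon bound to an aromatic nitrogen gives a 1.4-fold higher number from compound 1 to compound 3 (0.14 log units; within the scatter), so this one exchange leaves the number unresolved from that of compound 1. The swap removes the chlorine and moves the substituent to a different ring position in a single step, and nothing available here explains the outcome.

Going by these compounds, it remains open whether 4-chlorophenyl or 2-methylphenyl would also stay within the scatter, which would help separate the identity of the substituent from its ring position. On these data alone, it is equally open whether a phenyl carrying an amine or a carboxylic acid, or a longer chain at this place, would move the number beyond the scatter.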